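Paw edema inhibition: methoxy count and oxime-to-ketone swap

This account rests on a few compounds, and the source may have more. Where it says the series, first, only, none or still open, it means among the compounds named here.

The series is read in a functional assay on the whole organism (strain albino) for inhibition, with Rattus norvegicus as the target, read by paw edema, with stated times of 30 min and 4 h, at a dose of 0.28 mmol/kg by the oral route; a lower number here means less inhibition, a higher number more inhibition at the dose given (going by the name of the read-out). Compound 1 `CCn1c(SCC(=O)Nc2ccc(/C(C)=N/O)cc2)nnc1-c1ccc(OC)c(OC)c1` gives 75%. Compound 2 `CCn1c(SCC(=O)Nc2ccc(/C(C)=N/O)cc2)nnc1-c1cc(OC)c(OC)c(OC)c1`, which carries one more methoxy group, gives 70%. Compound 3 `CCn1c(SCC(=O)Nc2ccc(C(C)=O)cc2)nnc1-c1ccc(OC)c(OC)c1` gives 69%.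

Two single-point changes are measured. From compound 2 to compound 1 the change is hydrogen in place of methoxy on an aromatic carbon, and the read-out moves by a number 5 percentage points higher from compound 2 to compound 1 (within the scatter). From compound 1 to compound 3 the oxime is exchanged for the ketone, and the read-out moves by a number 6 percentage points lower from compound 1 to compound 3 (within the scatter). The number for compound 3 sits within the scatter of both compound 1 and compound 2; the three values are not separated by these measurements. The difference between the cores of compound 3 and compound 2 is not broken down here.

Compound 4 `CCn1c(SCC(=O)Nc2ccc(C(C)=O)cc2)nnc1-c1ccc(OC)cc1` has not yet been measured. It differs from compound 3 by hydrogen in place of methoxy on an aromatic carbon. This is the same kind of change as from compound 2 to compound 1, though the surroundings are not identical: in compound 2 the leaving methoxy is also meta to a methoxy group, while in compound 3 it is only ortho to a methoxy group and meta to a large group. The step from compound 3 to compound 4 is expected to be a number 1 percentage points higher from compound 3 to compound 4 (within the scatter), resting on the earlier step of a number 5 percentage points higher from compound 2 to compound 1 (within the scatter), which stayed within the scatter. Compound 4 is therefore estimated at 70% in this assay, with a likely range from 56% to 82%.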

Compound 4, a percentage reported as inhibition, in the whole organism at one dose (the size of the read-out at that dose, not a potency): 65%
Compound 4: middle estimate off by 5 percentage points, on the high side; the range from low to high includes it.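

In this assay, the change from 3,4-dimethoxyphenyl to 4-methoxyphenyl gives a number 4 percentage points lower from compound 3 to compound 4 (within the scatter). Set beside the earlier loss of a methoxy group on the oxime core, the two steps cannot be told apart: the same change on two cores in this assay, a number 5 percentage points higher (within the scatter) from compound 2 to compound 1 and a number 4 percentage points lower (within the scatter) from compound 3 to compound 4, 9 percentage points apart, within the scatter of two such steps. This shows no measurable dependence of the change on the core in these two cases, and neither step shows any effect of the methoxy group on the read-out; it does not show that the change transfers reliably, as the two steps point opposite ways, each stays within the scatter, they start from different methoxy patterns, and a single-dose read-out leaves real differences of this size undetected.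

Open questions are how the oxime partner of compound 4 and the ketone partner of compound 2 would read, as these would complete the comparison of methoxy count across both cores. The compounds shown also leave open what happens at the aromatic ring with a plain phenyl group or with a hydroxy group or an amine in place of the remaining methoxy, and what a longer chain in place of the ethyl group would do.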